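The source may report more compounds than this note shows. Statements on the series, on what has been measured and on what is new or still open speak of the compounds shown alone.

Compound 1 `CCC(=O)c1ccc2c(c1O)[C@H]1c3c(ccc4c(=O)c(C)coc34)OC[C@H]1C(C)(C)O2` and compound 2 `CC(=O)c1ccc2c(c1O)[C@H]1c3c(ccc4c(=O)c(C)coc34)OC[C@H]1C(C)(C)O2` share a core; compound 3 `CCC(=O)c1ccc2c(c1O)[C@@H]1c3c(ccc4c(=O)c(-c5ccccc5)c(C)oc34)OC[C@@H]1C(C)(C)O2` and compound 4 `CC(=O)c1ccc2c(c1O)[C@@H]1c3c(ccc4c(=O)c(-c5ccccc5)c(C)oc34)OC[C@@H]1C(C)(C)O2` share another, and the difference between the two cores is not broken down here. In a functional assay on HeLa cells (Homo sapiens) for cytotoxicity, read by MTT assay (a lower number here means a stronger inhibitor, a higher number a weaker inhibitor), compound 1 gives only a limit, > 100000 nM. Compound 2 likewise gives only a limit in this assay, > 100000 nM. Compound 3 gives a number in this assay, 18200 nM. Within the pair of compounds 1 and 2 the change is hydrogen in place of methyl on a saturated chain carbon bound to a carbonyl carbon; the step that the two limits leave unreadable from compound 1 to compound 2 cannot be sized, since the limit of > 100000 nM in this assay, at which 2 of the 3 values shown sit, applies to both ends. The same change, (hydrogen in place of methyl on a saturated chain carbon bound to a carbonyl carbon), carries compound 3 to compound 4. For the measured compounds named here, from compound 3 to compound 4 a step of a 1.2-fold higher number from compound 3 to compound 4 (0.08 log units; within the scatter) is expected in this assay, a small one, because the only measured instance of this change, a step that the two limits leave unreadable from compound 1 to compound 2, gives no readable size and offers nothing to suggest a large shift either way. Compound 4 is therefore estimated at 22000 nM, with a plausible range from 7000 nM to 70000 nM.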

Compound 4, half-maximal inhibitory concentration: 4810 nM
Estimate against measurement, compound 4: 4.6-fold (0.66 log units) above; the whole stated range lies above it.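

In this assay, hydrogen in place of methyl on a saturated chain carbon bound to a carbonyl carbon, here propanoyl to acetyl, gives a 3.8-fold lower number from compound 3 to compound 4 (0.58 log units; beyond the scatter), a modest step, so on this core the change does register. This single readable instance sets no rule for any other core. The same change on the core of compound 1 cannot be read, and whether the step carries over from one core to the other, in size or in direction, stays unshown, because compound 1 and compound 2 both sit at a limit of the assay rather than at a number: the limit of > 100000 nM in this assay, at which 2 of the 4 values shown sit.

The compounds shown carry only propanoyl and acetyl at this place, so it remains open how a longer chain such as butanoyl, or an amine or a carboxylic acid there, would read in this assay. Also open, as far as these compounds go, is how the change would read on a further core where both members of the pair give numbers.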